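Cytotoxicity notes: varying the pendant aryl on the shared core

This account rests on a few compounds, and the source may have more. Where it says the series, first, only, none or still open, it means among the compounds named here.

Of the compounds shown here, three on the shared core have been measured in an ADME assay on MT4 cells (Homo sapiens) for cytotoxicity, read by MTT assay, with a stated time of 4 days; a higher number here means that more compound is tolerated, a lower number that less compound is tolerated. Compound 1 `Cc1cc(-c2ccc(C#N)cc2)cc(C)c1Nc1ccnc(Nc2ccc(C#N)cc2)n1` gives 2080 nM. Compound 2 `Cc1cc(-c2ccccc2)cc(C)c1Nc1ccnc(Nc2ccc(C#N)cc2)n1` gives 4170 nM. Compound 3 `Cc1cc(-c2cc(Cl)cc(Cl)c2)cc(C)c1Nc1ccnc(Nc2ccc(C#N)cc2)n1` gives 4290 nM. Compound 3 and compound 2 sit together at the tolerant end of these three numbers, since the step of a 1.0-fold higher number from compound 2 to compound 3 (0.01 log units; within the scatter) is within the scatter, whereas against compound 1 the step of a 2.1-fold higher number from compound 1 to compound 3 (0.31 log units; beyond the scatter) is beyond it, if only modestly. The step of a 2.0-fold higher number from compound 1 to compound 2 (0.30 log units; within the scatter) is likewise within the scatter.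

Compound 4 `Cc1cc(-c2ccccc2F)cc(C)c1Nc1ccnc(Nc2ccc(C#N)cc2)n1` is not yet measured. Its change from compound 3 is 2-fluorophenyl in place of 3,5-dichlorophenyl on an aromatic carbon. Among the compounds with values here, no measured step tests a 2-fluorophenyl directly. Within the data shown here, the nearest precedent is the exchange of phenyl for 3,5-dichlorophenyl, where a 1.0-fold higher number from compound 2 to compound 3 (0.01 log units; within the scatter) showed no movement beyond the scatter; only the pendant 4-cyanophenyl of compound 1 stood apart. On this basis the step from compound 3 to compound 4 in this assay is expected to stay within the scatter, a 1.0-fold lower number from compound 3 to compound 4 (0.01 log units; within the scatter), with no preferred direction. Compound 4 is therefore estimated at 4200 nM, in a range from 2100 nM to 8400 nM.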

Compound 4, half-maximal cytotoxic concentration: 2120 nM
Beside the measured number, compound 4's estimate is 2.0-fold (0.30 log units) above it, and the stated range covers the measured number.
By their numbers in this assay, from the lowest: compounds 1, 4, 2 and 3 (each within the scatter of the next, the first and the last beyond it).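

The exchange in this assay shows that compound 3 is no longer set apart by compound 1 alone: a 2.0-fold lower number from compound 3 to compound 4 (0.31 log units; beyond the scatter) is a modest step beyond the scatter, made with a group that carries no nitrile. Fluoro in place of hydrogen on the pendant ring gives a 2.0-fold lower number from compound 2 to compound 4 (0.29 log units; within the scatter) and so stays inside the scatter, while a 1.0-fold higher number from compound 1 to compound 4 (0.01 log units; within the scatter) leaves 2-fluorophenyl level with 4-cyanophenyl. The low end of these four numbers is therefore not tied to the nitrile, although compound 2, within the scatter of compound 1, compound 3 and compound 4, keeps the series from splitting into two clear groups.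

On these data alone, whether a pendant ring bearing an amine or a carboxylic acid would stay in this narrow band remains open. Nothing at hand bears on what lies behind these small differences.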